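Benzyl to 4-methylphenyl in compound 3

The compounds below may be only part of what the source reports. "The series", "measured", "known", "first", "only" and "open" are said of these compounds alone.

In a functional assay on NB1 cells (Homo sapiens) for antiproliferative activity, with a stated time of 72 h (on this read-out higher numbers stand for weaker inhibition and lower numbers for stronger inhibition), compound 1 (`Cc1ccc(NC(=O)CCN(Cc2ccc(C(=O)NO)cc2)C(=O)c2cc(C)cc(C)c2)cc1`) gives 670 nM, compound 2 (`Cc1ccc(NC(=O)CCN(Cc2ccc(C(=O)NO)cc2)C(=O)c2ccccc2)cc1`) gives 1480 nM and compound 3 (`CN(C)c1ccc(C(=O)N(CCC(=O)NCc2ccccc2)Cc2ccc(C(=O)NO)cc2)cc1`) gives 1720 nM. Compound 3 thus sits within the scatter of compound 2, while its number is higher than that of compound 1 by more than the scatter.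

Compound 4 (`Cc1ccc(NC(=O)CCN(Cc2ccc(C(=O)NO)cc2)C(=O)c2ccc(N(C)C)cc2)cc1`) carries 4-methylphenyl in place of benzyl on an amide-type nitrogen. Within the data shown here, no measured step makes this exact change. Among the measured compounds shown here, the one measured step, a 2.2-fold higher number from compound 1 to compound 2 (0.34 log units; beyond the scatter), lies at a carbonyl carbon elsewhere in the molecule, so it bears only indirectly, showing a modest move in compounds that already hold 4-methylphenyl. Compound 4 shares that group with compound 2, which gives 1480 nM, level with compound 3 despite differing from it in more than one place. A small move towards a lower number in this assay is therefore expected, probably not beyond the scatter. The expected result is a 1.6-fold lower number from compound 3 to compound 4 (0.19 log units; within the scatter). For compound 4 the estimated value is 1100 nM, with an expected range of 450 nM to 2600 nM.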

Compound 4, half-maximal inhibitory concentration: 660 nM
For compound 4 the middle estimate is 1.7-fold (0.22 log units) above the measured one; the measured number falls inside the stated range.
By their numbers in this assay, from the lowest: compounds 4 and 1 (each within the scatter of the next); then compounds 2 and 3 (each within the scatter of the next).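

In this assay, the amide-type nitrogen proves to be a place where the number can move: 4-methylphenyl in place of benzyl gives a 2.6-fold lower number from compound 3 to compound 4 (0.42 log units; beyond the scatter), the only step shown at this position. On the carbonyl carbon, dimethylamino in place of hydrogen on an aromatic carbon gives a 2.2-fold lower number from compound 2 to compound 4 (0.35 log units; beyond the scatter), while 4-(dimethylamino)phenyl in place of 3,5-dimethylphenyl gives a 1.0-fold lower number from compound 1 to compound 4 (0.01 log units; within the scatter), so these two groups cannot be told apart in this read-out. Nothing measured here offers an explanation for these steps.

Going by these compounds, the change from benzyl to 4-methylphenyl is seen in one pair only, so whether it gives a similar step with phenyl or 3,5-dimethylphenyl on the carbonyl carbon remains open. Also open, on these data alone, is how a 4-chlorophenyl or a 2-phenylethyl group would read on that amide-type nitrogen.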